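A few compounds are considered here, and "the series" means these few. Any claim that something is new, unique, unknown or untested is made for them only; others in the source may bear on it.

Measured so far in a functional assay for binding affinity to metabotropic glutamate receptor 2 (Homo sapiens), read by GTPgammaS binding, with a stated time of 1 h, at 30 degrees C; a lower number here means that less compound is needed, a higher number that more compound is needed for the effect:

Compound 1, `CCCc1c(OCCCCOc2ccc(-c3nn[nH]n3)cc2)ccc2c1CCN2CC(C)(C)C`: 1170 nM
Compound 2, `CCCc1c(OCCCCOc2ccc(-c3nn[nH]n3)cc2)ccc2c1ncn2CC(C)(C)C`: 6370 nM
Compound 3, `CCCc1c(OCCCCOc2ccc(-c3nn[nH]n3)cc2)ccc2c1ccn2CCC`: 652 nM

All three carry the same chain from the core to the tetrazolyl-phenyl end and differ only in the fused bicyclic core and the group on its nitrogen. Compound 3 gives the smallest of the three numbers in this assay. Its gap to compound 1 lies within the usual scatter, so no order between compound 3 and compound 1 can be read from these two values; the gap to compound 2 lies beyond the scatter.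

Compound 4, `CCCc1c(OCCCCOc2ccc(-c3nn[nH]n3)cc2)ccc2c1ccn2C(C)C`, is the next compound of the series. The change from compound 3 is isopropyl in place of propyl on an aromatic nitrogen. Within the data shown here, no pair of measured compounds separated by a single change is available, so the size of this step cannot be anchored on a measured one. A change of this kind, same atoms joined differently on the ring nitrogen, is expected to move the number little, in either direction, most likely within the scatter.

For compound 4 the expected value in this assay is 800 nM, with a range from 350 nM to 1900 nM. The step from compound 3 to compound 4 is thus expected to be a 1.2-fold higher number from compound 3 to compound 4 (0.09 log units; within the scatter), not beyond the scatter.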

Compound 4, half-maximal effective concentration: 1130 nM
Compound 4: the middle estimate sits 1.4-fold (0.15 log units) below what was measured; the measured number falls inside the stated range.
By their numbers in this assay, from the lowest: compounds 3, 4 and 1 (each within the scatter of the next); then compound 2.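

In this assay, among these compounds, isopropyl in place of propyl on an aromatic nitrogen gives a 1.7-fold higher number from compound 3 to compound 4 (0.24 log units; within the scatter) and so supplies the first step that changes one place only. At this position, joining the same atoms differently leaves no order that can be read between the two compounds, and this single pair gives no sign that the position separates these two groups. Among the compounds shown here, nothing measured so far offers an explanation for the size of this step.

Still open, from the compounds shown here alone, is how this nitrogen responds to groups of another kind, such as a longer chain, a cyclopropyl ring, or a chain ending in an amine or a carboxylic acid. Compound 1 and compound 2 each differ from compound 3 in both the core and the group on nitrogen, so the share of each change in their numbers remains unseparated.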